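This account rests on a few compounds, and the source may have more. Where it says the series, first, only, none or still open, it means among the compounds named here.

Three compounds that share one core but differ at the amide-type nitrogen have been examined in an assay on cells for agonist activity at vitamin D3 receptor (Homo sapiens), with a stated time of 96 h; a higher number here means that more compound is needed for the effect, a lower number that less compound is needed. Compound 1 `CCn1c(C(=O)NCCN)ccc1C(CC)(CC)c1ccc(OCCC(O)(CC)CC)c(C)c1` gives 156 nM, compound 2 `CCOc1ccc(NC(=O)c2ccc(C(CC)(CC)c3ccc(OCCC(O)(CC)CC)c(C)c3)n2CC)cc1` gives 1630 nM, and compound 3 `CCOC(=O)CN(C)C(=O)c1ccc(C(CC)(CC)c2ccc(OCCC(O)(CC)CC)c(C)c2)n1CC` gives 520 nM. Compound 3 thus stands in the middle of the three: there is a 3.3-fold higher number from compound 1 to compound 3 (0.52 log units; beyond the scatter), and a 3.1-fold lower number from compound 2 to compound 3 (0.50 log units; beyond the scatter), while the widest gap is a 10-fold higher number from compound 1 to compound 2 (1.02 log units; beyond the scatter).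

Compound 4 `CCn1c(C(=O)NC(CC(=O)O)C(=O)OC)ccc1C(CC)(CC)c1ccc(OCCC(O)(CC)CC)c(C)c1` carries, on the carbonyl carbon whose other neighbour is an aromatic carbon, (a group of 10 heavy atoms (5 carbon, 1 nitrogen, 4 oxygen; no ring) in place of a group of 8 heavy atoms (5 carbon, 1 nitrogen, 2 oxygen; no ring), on a carbonyl carbon). The steps from compound 1 and compound 2 to compound 3 bear on this change, both modest in size and in opposite directions, so the amide substituent can move this assay in either direction. With a group that is neither the 2-aminoethyl chain of compound 1 nor the 4-ethoxyphenyl of compound 2, compound 4 is expected to show a 1.2-fold higher number from compound 3 to compound 4 (0.06 log units; within the scatter), that is a value near compound 3, within the scatter. The estimate for compound 4 is therefore 600 nM, with a range from 150 nM to 2500 nM.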

Compound 4, half-maximal effective concentration: 26 nM
Compound 4: the middle estimate sits 23-fold (1.36 log units) above what was measured; measured number outside the range, below it.
By their numbers in this assay, from the lowest: compound 4; then compound 1; then compound 3; then compound 2.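

In this assay, replacing ((ethoxycarbonyl)methyl)(methyl)amino on the carbonyl carbon with the group of compound 4 gives a 20-fold lower number from compound 3 to compound 4 (1.30 log units; beyond the scatter), so a change at this place between two ringless groups can be large. Compound 4 also sits clearly below both other compounds, with a 6.0-fold lower number from compound 1 to compound 4 (0.78 log units; beyond the scatter) and a 63-fold lower number from compound 2 to compound 4 (1.80 log units; beyond the scatter), which shows that this position can reach lower numbers than the 2-aminoethyl chain of compound 1 gave. The amide hydrogen alone does not account for this order, since compound 2 carries it too and has the highest number of the four.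

Which part of the entering group matters remains open, and a shorter chain with a single carboxylic acid and no ester, or a chain ending in a hydroxyl group, would help to separate its parts. No evidence accompanies these values that could explain the step.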